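Working notes on methyl additions in a small series

This account rests on a few compounds, and the source may have more. Where it says the series, first, only, none or still open, it means among the compounds named here.

Measured in a functional assay on MDA-MB-231 cells (Homo sapiens) for inhibition, read by CCK-8 assay, with a stated time of 48 h (a higher number here means a weaker inhibitor of growth, a lower number a stronger inhibitor of growth), so far:
compound 1 `Cc1ccccc1Nc1nc(Nc2ccc(N3CCN(C)CC3)cn2)ncc1Cl`: 7470 nM
compound 2 `CCN1CCN(c2ccc(Nc3ncc(Cl)c(Nc4ccccc4C)n3)nc2)CC1`: > 100000 nM
compound 3 `CCc1ccc(Nc2nc(Nc3ccc(N4CCN(C)CC4)cn3)ncc2Cl)cc1`: 5560 nM

The value of compound 2 is a limit of the assay and not a number (the limit of > 100000 nM in this assay, at which 1 of the 3 values shown sits).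

Compound 1 and compound 2 differ by methyl in place of hydrogen on a saturated chain carbon bound to an amine nitrogen in a ring, and the step is an at least 13-fold higher number from compound 1 to compound 2 (1.12 log units; beyond the scatter). Compound 1 and compound 3 differ in their cores by 4-ethylphenyl in place of 2-methylphenyl on a nitrogen on an aromatic ring; the step of a 1.3-fold lower number from compound 1 to compound 3 (0.13 log units; within the scatter) is within the scatter, so the two values are not told apart here.

Compound 4 `CC(C)c1ccc(Nc2nc(Nc3ccc(N4CCN(C)CC4)cn3)ncc2Cl)cc1` is not yet measured. It differs from compound 3 by methyl in place of hydrogen on a saturated chain carbon bound to an aromatic carbon and a saturated chain carbon. For the measured compounds named here, this is the same kind of change as the one from compound 1 to compound 2, a methyl in place of hydrogen, but not the same: there the place was a saturated chain carbon bound to an amine nitrogen in a ring, here it is a saturated chain carbon bound to an aromatic carbon and a saturated chain carbon. Going by the values given here, the large step seen as an at least 13-fold higher number from compound 1 to compound 2 (1.12 log units; beyond the scatter) therefore cannot be carried over directly, and no measured pair shows a methyl added at this second kind of place.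

For compound 4 the expected step is a 1.1-fold higher number from compound 3 to compound 4 (0.03 log units; within the scatter), resting only on compound 3 giving 5560 nM and on the change being a single added carbon with no donor or acceptor. Compound 4 is thus estimated at 6000 nM, with a range from 2500 nM to 15000 nM.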

Compound 4, concentration for 50% growth inhibition: 7020 nM
Estimate against measurement, compound 4: 1.2-fold (0.07 log units) below; the range from low to high includes it.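

In this assay, a methyl in place of hydrogen on a saturated chain carbon bound to an aromatic carbon and a saturated chain carbon gives a 1.3-fold higher number from compound 3 to compound 4 (0.10 log units; within the scatter), and the other new pair gives a 1.1-fold lower number from compound 1 to compound 4 (0.03 log units; within the scatter), so neither step tells its two compounds apart. Set beside the earlier methyl addition, this shows that a methyl in place of hydrogen does not carry a single step size from one core to another in this series: the same change on two cores in this assay, an at least 13-fold higher number (1.12 log units; beyond the scatter) from compound 1 to compound 2 and a 1.3-fold higher number (0.10 log units; within the scatter) from compound 3 to compound 4, at least 10-fold (1.02 log units) apart, beyond the scatter of two such steps The value of compound 2, > 100000 nM, is a limit of the assay and not a number, and since the two methyls also sit at different places, the pair does not show whether the core or the place goes with the gap.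

The compounds shown leave open whether a methyl on the saturated chain carbon bound to an amine nitrogen in a ring gives a large step on the core of compound 3 as well. They also leave open whether the flat readings across the 4-ethylphenyl and 4-isopropylphenyl compounds hold for a longer chain, such as butyl, or for an amine or a carboxylic acid at that place.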